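Working notes: compound 4 after the methoxy-to-dimethyl change

This account rests on a few compounds, and the source may have more. Where it says the series, first, only, none or still open, it means among the compounds named here.

Measured so far:
compound 1 `CCc1ccccc1NS(=O)(=O)c1ccc(N2CCNC2=O)cc1` — in a functional assay on M21 cells (Homo sapiens) for antiproliferative activity, read by sulforhodamine B assay, with a stated time of 48 h (a lower number here means a stronger inhibitor, a higher number a weaker inhibitor), compound 1 gives 180 nM
compound 2 `Cc1ccccc1NS(=O)(=O)c1ccc(N2CCNC2=O)cc1` — in this assay compound 2 gives 150 nM
compound 3 `COc1ccccc1NS(=O)(=O)c1ccc(N2CCNC2=O)cc1` — in this assay compound 3 gives 300 nM

Compound 3 has the highest number of the three, yet its distance to both neighbours stays within the scatter: a 1.7-fold higher number from compound 1 to compound 3 (0.22 log units; within the scatter) and a 2.0-fold higher number from compound 2 to compound 3 (0.30 log units; within the scatter). Compound 4 `Cc1cccc(NS(=O)(=O)c2ccc(N3CCNC3=O)cc2)c1C` carries the change (2,3-dimethylphenyl in place of 2-methoxyphenyl on a sulfonamide nitrogen). Going by the values given here, the steps that bear on it are a 2.0-fold higher number from compound 2 to compound 3 (0.30 log units; within the scatter), read in reverse, and a 1.2-fold lower number from compound 1 to compound 2 (0.08 log units; within the scatter); both are small. Among the compounds with values here, no measured compound carries a second methyl, so that part of the change is untested. The expectation is therefore a number near those of compound 1 and compound 2, a step of a 1.7-fold lower number from compound 3 to compound 4 (0.22 log units; within the scatter) that stays within the scatter. Compound 4 is estimated at 180 nM, with a range of 90 nM to 360 nM.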

Compound 4, half-maximal inhibitory concentration: 110 nM
Estimate against measurement, compound 4: 1.6-fold (0.21 log units) above, and the stated range covers the measured number.
By their numbers in this assay, from the lowest: compounds 4, 2, 1 and 3 (each within the scatter of the next, the first and the last beyond it).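

In this assay, going by these compounds alone, the change from 2-methoxyphenyl to 2,3-dimethylphenyl on a sulfonamide nitrogen gives a 2.7-fold lower number from compound 3 to compound 4 (0.44 log units; beyond the scatter) and is the only step beyond the scatter. A methyl in place of hydrogen on an aromatic carbon gives a 1.4-fold lower number from compound 2 to compound 4 (0.13 log units; within the scatter) and the exchange of 2-ethylphenyl for 2,3-dimethylphenyl gives a 1.6-fold lower number from compound 1 to compound 4 (0.21 log units; within the scatter) so compound 4 separates from compound 3 alone. No available evidence bears on the reason for this step.

From the compounds shown here alone, whether the 2,3-dimethylphenyl group tolerates a longer chain, an amine or a carboxylic acid in place of either methyl remains open.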